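A few compounds are considered here, and "the series" means these few. Any claim that something is new, unique, unknown or untested is made for them only; others in the source may bear on it.

In an ADME assay on microsomes from liver (Canis lupus familiaris) for metabolic stability (on this read-out higher numbers stand for a longer-lived compound and lower numbers for a shorter-lived compound), two compounds on a shared core have been measured so far. Compound 1 `Nc1nc(NCCNc2ncc(-c3ncc[nH]3)c(-c3ccccc3Br)n2)ccc1[N+](=O)[O-]` gives > 0.5 h, which is a limit of the assay and not a number. Compound 2 `Nc1nc(NCCNc2ncc(-c3ncc[nH]3)c(-c3cc(F)c(F)cc3F)n2)ccc1[N+](=O)[O-]` gives > 0.5 h, which is likewise only a limit. Compound 2 therefore has no exact value of its own, and the whole picture in this assay is the limit of > 0.5 h in this assay, at which 2 of the 2 values shown sit.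

Compound 3 `Nc1nc(NCCNc2ncc(-c3ncc[nH]3)c(-c3ccc(Cl)cc3F)n2)ccc1[N+](=O)[O-]` carries 4-chloro-2-fluorophenyl in place of the 2,4,5-trifluorophenyl of compound 2, on the same aromatic carbon of the six-membered aromatic ring with 2 nitrogen: 4-chloro-2-fluorophenyl in place of 2,4,5-trifluorophenyl on an aromatic carbon.

Among the compounds with values here, only one measured step bears on this change, an exchange of the aryl group at that same carbon. It is a step that the two limits leave unreadable from compound 1 to compound 2, so it offers no size and no direction to carry over. Since both aryl exchanges keep a halogenated phenyl there, no shift beyond the usual scatter is expected, and neither direction is favoured. The expected step is a step that the limit leaves unreadable from compound 2 to compound 3. Compound 3 is estimated at 0.8 h, with an expected range from 0.5 h to 1.6 h.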

Compound 3, half-life: > 0.5 h
Compound 3 gave a limit, no number; the forecaster's own chance of this, stated with the estimate: 80%; the middle value lies beyond the limit too.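

In this assay compound 3 gives > 0.5 h, which is a limit and not a number. Within the data shown here, no step among compound 1, compound 2 and compound 3 can be read, and the picture stays as it was: the limit of > 0.5 h in this assay, at which 3 of the 3 values shown sit. The compounds shown leave open what half-life each actually has, and whether exchanging the aryl group changes it at all.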